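Taking the ring bare: what to expect for compound 4

The compounds below may be only part of what the source reports. "The series", "measured", "known", "first", "only" and "open" are said of these compounds alone.

Compound 1 `COc1cc(C=C2C(=O)N(c3ccc(Cl)cc3)N(c3ccc(Cl)cc3)C2=O)ccc1O` is the reference here. In a functional assay on ECa-109 cells (Homo sapiens) for cytotoxicity, read by MTT assay, with a stated time of 72 h (on this read-out higher numbers stand for weaker inhibition and lower numbers for stronger inhibition), compound 1 gives 7100 nM, which is the highest of the two plain numbers known; the nearest is compound 3 `COc1cccc(C=C2C(=O)N(c3ccc(Cl)cc3)N(c3ccc(Cl)cc3)C2=O)c1OC`, which gives 6800 nM in this assay, and a 1.0-fold lower number from compound 1 to compound 3 (0.02 log units; within the scatter). Compound 2 `COc1ccc(C=C2C(=O)N(c3ccc(Cl)cc3)N(c3ccc(Cl)cc3)C2=O)cc1` reached only a limit in this assay, reported as > 128000 nM. From these, an at least 18-fold higher number from compound 1 to compound 2 (1.25 log units; beyond the scatter) and an at least 18-fold lower number from compound 2 to compound 3 (1.27 log units; beyond the scatter), both resting on (the limit of > 128000 nM in this assay, at which 1 of the 3 values shown sits).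

Compound 4 `O=C1C(=Cc2ccccc2)C(=O)N(c2ccc(Cl)cc2)N1c1ccc(Cl)cc1` differs from compound 1 as follows: phenyl in place of 4-hydroxy-3-methoxyphenyl on a double-bonded chain carbon bound to a double-bonded ring carbon. Within the data shown here, the step that bears most on this change is the one from compound 1 to compound 2, where losing only the hydroxyl was enough for a large rise, and losing more of the oxygen substituents is expected to behave in the same direction. A large step upward in this assay is therefore expected, so that an 8.5-fold higher number from compound 1 to compound 4 (0.93 log units; beyond the scatter). Compound 4 is estimated to give 60000 nM in this assay, with a range from 10000 nM to 300000 nM, and a real chance that only a limit is reported.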

Compound 4, half-maximal inhibitory concentration: 32700 nM
Estimate against measurement, compound 4: 1.8-fold (0.26 log units) above; the range from low to high includes it.
By their numbers in this assay, from the lowest: compounds 3 and 1 (each within the scatter of the next); then compound 4. At a limit, above all of these: compound 2.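

In this assay, stripping the ring down to bare phenyl costs only a modest amount against either of the two rings that carry two oxygen substituents: a 4.6-fold higher number from compound 1 to compound 4 (0.66 log units; beyond the scatter), and a 4.8-fold higher number from compound 3 to compound 4 (0.68 log units; beyond the scatter). Compound 2 gave only a limit, > 128000 nM. Even so, an at least 3.9-fold lower number from compound 2 to compound 4 (0.59 log units; beyond the scatter), so the number does not fall steadily as oxygen substituents are added to this ring; compound 2, with its single methoxy, goes against any such trend, and this reading rests on a limit: the limit of > 128000 nM in this assay, at which 1 of the 4 values shown sits.

The compounds shown leave open how a phenyl ring carrying a single hydroxyl, with no methoxy, would compare with compound 4. They also leave open whether an amine or a carboxylic acid on this ring would give a number closer to compound 1 or to compound 4.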